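The compounds below may be only part of what the source reports. "The series", "measured", "known", "first", "only" and "open" are said of these compounds alone.

Measured in a functional assay on CCRF-CEM cells (Homo sapiens); on this read-out lower numbers stand for higher toxicity in this test and higher numbers for lower toxicity in this test:
- compound 1 `COC(=O)Cn1c(=O)c(C)cn([C@@H]2O[C@H](CO[Si](C)(C)C(C)(C)C)[C@@]3(OS(=O)(=O)C=C3N)[C@H]2O[Si](C)(C)C(C)(C)C)c1=O` gives > 152000 nM, a limit of the assay
- compound 2 `Cc1cn([C@@H]2O[C@H](CO[Si](C)(C)C(C)(C)C)[C@@]3(OS(=O)(=O)C=C3N)[C@H]2O[Si](C)(C)C(C)(C)C)c(=O)n(CC(N)=O)c1=O` gives 13300 nM
- compound 3 `CCOC(=O)CCCCCn1c(=O)c(C)cn([C@@H]2O[C@H](CO[Si](C)(C)C(C)(C)C)[C@@]3(OS(=O)(=O)C=C3N)[C@H]2O[Si](C)(C)C(C)(C)C)c1=O` gives 40600 nM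

Of the two actual numbers, compound 3 holds the higher one. Compound 4 `Cc1cn([C@@H]2O[C@H](CO[Si](C)(C)C(C)(C)C)[C@@]3(OS(=O)(=O)C=C3N)[C@H]2O[Si](C)(C)C(C)(C)C)c(=O)n(CCCNC(=O)OCc2ccccc2)c1=O` departs from compound 3 by (benzyloxycarbonyl)amino in place of 2-(ethoxycarbonyl)ethyl on a saturated chain carbon, three bonds along the chain from an aromatic nitrogen.

Three measured changes to this side chain bear on the step: an at least 11-fold lower number from compound 1 to compound 2 (1.05 log units; beyond the scatter), then an at least 3.7-fold lower number from compound 1 to compound 3 (0.57 log units; beyond the scatter), and a 3.1-fold higher number from compound 2 to compound 3 (0.48 log units; beyond the scatter). The step between the two actual numbers is modest, so a small move toward compound 2 is expected. The expected step is a 1.8-fold lower number from compound 3 to compound 4 (0.27 log units; within the scatter). Compound 4 is estimated at 22000 nM, with an expected range of 6000 nM to 80000 nM.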

Compound 4, half-maximal cytotoxic concentration: 229000 nM
For compound 4 the middle estimate is 10-fold (1.02 log units) below the measured one, outside the stated range (above it).
By their numbers in this assay, from the lowest: compound 2; then compound 3; then compound 4.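

In this assay, (benzyloxycarbonyl)amino in place of 2-(ethoxycarbonyl)ethyl on a saturated chain carbon, three bonds along the chain from an aromatic nitrogen, gives a 5.6-fold higher number from compound 3 to compound 4 (0.75 log units; beyond the scatter). Compound 4 thus holds the highest of the three actual numbers, so the number at this position can rise as well as fall with a change at the end of the side chain. Compound 1 carries only a limit, and no order against compound 4 can be read from it: the limit of > 152000 nM in this assay, at which 1 of the 4 values shown sits.

On these data alone, whether a free amine or a carboxylic acid in this place would bring the number down remains open. So does the effect of a longer chain carrying (benzyloxycarbonyl)amino.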